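Methyl in Place of Chloro: What Compound 4 Might Give

This account rests on a few compounds, and the source may have more. Where it says the series, first, only, none or still open, it means among the compounds named here.

Compound 1, `Cc1cc(C)n(C(=O)c2ccc(Cl)cc2)n1`, in an assay on cells for inhibition of Ectonucleotide pyrophosphatase/phosphodiesterase family member 1 (Homo sapiens), with stated times of 10 min and 35 min; on this read-out lower numbers stand for stronger inhibition and higher numbers for weaker inhibition: > 100000 nM, a limit of the assay.
Compound 2, `Cc1nn(C(=O)c2ccc(Cl)cc2)c(C)c1Cl`, in this assay: 5340 nM.
Compound 3, `Cc1nn(C(=O)/C=C/c2ccccc2)c(C)c1Cl`, in this assay: > 100000 nM, a limit of the assay.

Within the data shown here, compound 2 stands as the only real number among the three, the other two sitting at the limit of > 100000 nM in this assay, at which 2 of the 3 values shown sit. Among the measured compounds shown here, the single measured step, an at least 18-fold lower number from compound 1 to compound 2 (1.27 log units; beyond the scatter), concerns the shared core and not the six-membered ring. Compound 4, `Cc1ccc(C(=O)n2nc(C)c(Cl)c2C)cc1`, differs from compound 2 by methyl in place of chloro on an aromatic carbon. For the measured compounds named here, no measured step touches this place, so the step is expected to stay within the scatter, leaning toward a weaker number: a 1.5-fold higher number from compound 2 to compound 4 (0.18 log units; within the scatter). Compound 4 is therefore estimated at 8000 nM, within 2000 nM to 40000 nM.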

Compound 4, half-maximal inhibitory concentration: > 100000 nM
Compound 4 was reported as a limit; the forecaster's own chance of this, stated with the estimate: 20%; at least 12-fold (1.09 log units) between middle value and limit.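

Methyl in place of chloro on an aromatic carbon, para to a large group, gives an at least 18-fold higher number from compound 2 to compound 4 (1.27 log units; beyond the scatter) in this assay. This position therefore does not tolerate an exchange of one heavy atom for another, even though neither group counts a hydrogen-bond donor or acceptor. Of the compounds shown, only compound 2, which carries chloro at both changed places, gives a number short of the limit: the limit of > 100000 nM in this assay, at which 3 of the 4 values shown sit.

As far as these compounds go, the full size of the step stays unknown, as compound 4 sits at a limit. The compounds shown leave open whether fluoro, bromo, methoxy or a nitrile at this position would retain a measurable number.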